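The source may report more compounds than this note shows. Statements on the series, on what has been measured and on what is new or still open speak of the compounds shown alone.

Working notes on the series. Compound 1 `[N-]=[N+]=N[C@H]1C[C@H](n2cnc3c(NCCO)nc(N)nc32)O[C@@H]1CO`, compound 2 `[N-]=[N+]=N[C@H]1C[C@H](n2cnc3c(N)nc(F)nc32)O[C@@H]1CO` and compound 3 `COc1nc(NC2CC2)c2ncn([C@H]3C[C@H](N=[N+]=[N-])[C@@H](CO)O3)c2n1` share a common core and were run together. In an ADME assay on Vero cells (Chlorocebus sabaeus) for cytotoxicity, with a stated time of 5 days (a lower number here means a stronger inhibitor, a higher number a weaker inhibitor), compound 2 gives 34400 nM. For compound 1 in this assay only a limit is recorded, > 100000 nM. Compound 3 likewise reaches only a limit in this assay, namely > 100000 nM. Where compound 3 stands is therefore defined by the limit of > 100000 nM in this assay, at which 2 of the 3 values shown sit, so no numbered value is attached to it and no step between measured compounds can be computed from it. Compound 4 `COc1nc(OC)c2ncn([C@H]3C[C@H](N=[N+]=[N-])[C@@H](CO)O3)c2n1` differs from compound 3 by methoxy in place of cyclopropylamino on an aromatic carbon. The change is small in size and removes the only hydrogen-bond donor on that part of the core, while compound 3 already sits at the limit, so for compound 4 in this assay no shift beyond the scatter is expected. In this assay the expected step is a number no higher from compound 3 to compound 4 (the limit leaves the size open), within the usual scatter. Compound 4 is estimated at 100000 nM in this assay, with a range from 30000 nM to 300000 nM, and a limit rather than a number is the more likely outcome.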

Compound 4, half-maximal inhibitory concentration: > 100000 nM
Compound 4: no number, only a limit; the forecaster's own chance of this, stated with the estimate: 75%; the middle value sits exactly at the limit.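

No step can be read from compound 3 to compound 4 in this assay, as both compounds give a limit and not a number: the limit of > 100000 nM in this assay, at which 3 of the 4 values shown sit.

The compounds shown leave open how far either lies past that limit, and whether methoxy in place of cyclopropylamino shifts the read-out at all.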